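Para substituent swap on a hydroxamate: trifluoromethoxy to nitro

This account rests on a few compounds, and the source may have more. Where it says the series, first, only, none or still open, it means among the compounds named here.

Three compounds have been measured in a functional assay on PC-3 cells (Homo sapiens) for inhibition, read by sulforhodamine B assay, with a stated time of 48 h; on this read-out higher numbers stand for weaker inhibition and lower numbers for stronger inhibition:
Compound 1 `CC[C@H](C)C(=O)O[C@H]1C[C@@H](C)C=C2C=C[C@H](C)[C@H](CC[C@@H](O)C[C@@H](CC(=O)NO)OC(C)=O)[C@H]21` gives 11400 nM.
Compound 2 `CC[C@H](C)C(=O)O[C@H]1C[C@@H](C)C=C2C=C[C@H](C)[C@H](CC[C@@H](O)C[C@@H](CC(=O)NO)OC(=O)c3ccccc3)[C@H]21` gives 3300 nM.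
Compound 3 `CC[C@H](C)C(=O)O[C@H]1C[C@@H](C)C=C2C=C[C@H](C)[C@H](CC[C@@H](O)C[C@@H](CC(=O)NO)OC(=O)c3ccc(OC(F)(F)F)cc3)[C@H]21` gives 20300 nM.

Compound 3 holds the highest number of the three. Its nearest neighbour is compound 1, within the scatter, and its furthest is compound 2, beyond the scatter. Compound 4 `CC[C@H](C)C(=O)O[C@H]1C[C@@H](C)C=C2C=C[C@H](C)[C@H](CC[C@@H](O)C[C@@H](CC(=O)NO)OC(=O)c3ccc([N+](=O)[O-])cc3)[C@H]21` differs from compound 3 in one place: nitro in place of trifluoromethoxy on an aromatic carbon, at a position para to a large group.

Going by the values given here, no measured step touches a nitro group. The step that bears most on this change is a 6.2-fold higher number from compound 2 to compound 3 (0.79 log units; beyond the scatter), which shows that a para substituent on the benzoyl ring can move the number appreciably in this assay. The other steps, a 3.5-fold lower number from compound 1 to compound 2 (0.54 log units; beyond the scatter) and a 1.8-fold higher number from compound 1 to compound 3 (0.25 log units; within the scatter), compare ester groups and give no further guide. Among the compounds with values here, with no direct precedent, the number for compound 4 is expected to lie near that of compound 3, and the step of a 1.7-fold lower number from compound 3 to compound 4 (0.23 log units; within the scatter) is estimated to stay within the scatter, with a wide range. Compound 4 is therefore estimated at 12000 nM, between 3000 nM and 45000 nM.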

Compound 4, half-maximal inhibitory concentration: 8200 nM
Beside the measured number, compound 4's estimate is 1.5-fold (0.17 log units) above it; the range from low to high includes it.
By their numbers in this assay, from the lowest: compound 2; then compounds 4, 1 and 3 (each within the scatter of the next, the first and the last beyond it).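

In this assay, nitro in place of trifluoromethoxy on the aromatic carbon para to a large group gives a 2.5-fold lower number from compound 3 to compound 4 (0.39 log units; beyond the scatter), so this place responds to an exchange of one substituent for another, not only to adding one where hydrogen stood. Nitro in place of hydrogen gives a 2.5-fold higher number from compound 2 to compound 4 (0.40 log units; beyond the scatter), the same direction as the earlier step to trifluoromethoxy, so both substituted compounds carry higher numbers than the unsubstituted compound 2. The 4-nitrophenyl group in place of methyl on the carbonyl carbon gives a 1.4-fold lower number from compound 1 to compound 4 (0.14 log units; within the scatter), which leaves these two compounds not told apart.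

No measurement bearing on these groups is available to account for the size of these steps. From the compounds shown here alone, whether an amine or a carboxylic acid at this place would also give a higher number than hydrogen remains open.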